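The source may report more compounds than this note shows. Statements on the series, on what has been measured and on what is new or still open speak of the compounds shown alone.

Compound 1 `CCN(C/C=C/C#CC(C)(C)C)Cc1cccc(OC[Si](C)(C)c2cccc(C)c2)c1` carries a 3-methylphenyl on its silicon, and in a functional assay on liver (Sus scrofa) for inhibition of squalene monooxygenase (Homo sapiens), using microsomes (a lower number here means a stronger inhibitor, a higher number a weaker inhibitor), compound 1 gives 3000 nM. Compound 2 `CCN(C/C=C/C#CC(C)(C)C)Cc1cccc(OC[Si](C)(C)c2ccc(C(N)=O)cc2)c1` bears a 4-carbamoylphenyl on the silicon instead, and in this assay compound 2 gives 5000 nM; the step of a 1.7-fold higher number from compound 1 to compound 2 (0.22 log units; within the scatter) stays within the scatter. Compound 3 `CCN(C/C=C/C#CC(C)(C)C)Cc1cccc(OC[Si](C)(C)CCc2ccccc2)c1` has a phenethyl on the silicon. In this assay compound 3 gives > 10000 nM, which is a limit of the assay rather than a measured number. The steps of an at least 3.3-fold higher number from compound 1 to compound 3 (0.52 log units; beyond the scatter) and an at least 2.0-fold higher number from compound 2 to compound 3 (0.30 log units; that floor lies within the scatter) both run toward weaker inhibition, and both end at that limit (the limit of > 10000 nM in this assay, at which 1 of the 3 values shown sits). Compound 4 `CCN(C/C=C/C#CC(C)(C)C)Cc1cccc(OC[Si](C)(C)C2CCCCC2)c1` differs from compound 3 by cyclohexyl in place of phenethyl on a silicon. Among the compounds with values here, no measured step covers an exchange of phenethyl for a saturated ring, so the expectation rests only on compound 3 already sitting at the limit. The step from compound 3 to compound 4 is expected to be a step that the limit leaves unreadable from compound 3 to compound 4, that is, no change beyond the scatter. For compound 4 the estimated value in this assay is 15000 nM, with a range from 5000 nM to 50000 nM, and a limit rather than a number is likely.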

Compound 4, half-maximal inhibitory concentration: 20000 nM
The estimate for compound 4 lay 1.3-fold (0.12 log units) below the measured number, and the stated range covers the measured number.
By their numbers in this assay, from the lowest: compounds 1 and 2 (each within the scatter of the next); then compound 4.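

In this assay, putting cyclohexyl on the silicon gives a 6.7-fold higher number from compound 1 to compound 4 (0.82 log units; beyond the scatter) and a 4.0-fold higher number from compound 2 to compound 4 (0.60 log units; beyond the scatter), and both steps lie beyond the scatter. Among compounds 1, 2 and 4, then, a six-membered ring on the silicon goes with a lower number when it is aromatic than when it is saturated, though this pattern rests on these three compounds alone. The step from compound 3 to compound 4 cannot be read, because compound 3 stands at a limit rather than at a number: the limit of > 10000 nM in this assay, at which 1 of the 4 values shown sits.

On these data alone, what remains open is how an unsubstituted phenyl, a pyridyl ring or a smaller saturated ring such as cyclopentyl would behave on the silicon. Also open, as far as these compounds go, is whether a hydroxyl or an amine on the cyclohexyl ring would bring the number back down.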